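The compounds below may be only part of what the source reports. "The series", "measured", "known", "first", "only" and "open" are said of these compounds alone.

In a functional assay on PANC-1 cells (Homo sapiens) for inhibition, read by MTT assay, with a stated time of 48 h (on this read-out higher numbers stand for weaker inhibition and lower numbers for stronger inhibition), compound 2 `Cc1ccc(Oc2c(/C=N/OCc3snnc3C)c(C)nn2C)cc1` is the starting point. Compound 2 gives > 50000 nM, which is a limit of the assay rather than a measured number. Two close relatives, each differing from it in one place, end the same way. Compound 1 `Cc1cccc(Oc2c(/C=N/OCc3snnc3C)c(C)nn2C)c1` gives > 50000 nM, again a limit. Compound 3 `Cc1nnsc1CO/N=C/c1c(C)nn(C)c1Oc1ccc(C(C)(C)C)cc1` gives > 50000 nM, also a limit. The steps a step that the two limits leave unreadable from compound 1 to compound 2 and a step that the two limits leave unreadable from compound 2 to compound 3 cannot be sized, because of the limit of > 50000 nM in this assay, at which 3 of the 3 values shown sit. Compound 4 `CCc1nnsc1CO/N=C/c1c(C)nn(C)c1Oc1ccc(C)cc1` differs from compound 2 by methyl in place of hydrogen on a saturated chain carbon bound to an aromatic carbon. For the measured compounds named here, no measured step touches this part of the molecule; the relatives only show that changes to the substituent on the phenyl group left the result at the limit, and nothing suggests that a small addition on the thiadiazolylmethyl side would move it. The step from compound 2 to compound 4 is expected to be a step that the limit leaves unreadable from compound 2 to compound 4, that is, no change readable within the scatter. Compound 4 is therefore expected to give 60000 nM, within 20000 nM to 200000 nM, and most likely to come back again only as a limit.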

Compound 4, half-maximal inhibitory concentration: > 50000 nM
Compound 4 was reported as a limit (the forecaster's own chance of this, stated with the estimate: 85%); the middle value is on the limit's open side.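

For the compounds shown here, no step from compound 2 to compound 4 can be read in this assay, because both results are limits rather than numbers: the limit of > 50000 nM in this assay, at which 4 of the 4 values shown sit. From the compounds shown here alone, how strongly any of compounds 1 to 4 inhibits remains open, as does whether these changes in structure affect inhibition at all.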